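From a methoxy group to a chlorine on the shared core

The source may hold more compounds than are shown below. What is called first, only, known or untested is meant among the compounds shown, and "the series" means these compounds.

For the measured compounds named here, compound 1 `COc1ccc(C2SCC(=O)N2NC(=O)CN2C(=O)c3ccccc3C2=O)cc1` has been measured in a physicochemical assay for lipophilicity, in phosphate buffer, measured as octanol-water partition, with a stated time of 24 h (on this read-out higher numbers stand for higher lipophilicity and lower numbers for lower lipophilicity), where compound 1 gives 1.97, the lower of the two numbers so far. Going by the values given here, its only measured neighbour is compound 2 `COc1ccc(C2SCC(=O)N2NC(=O)CN2C(=O)c3ccccc3C2=O)cc1OC`, which in this assay gives 2.78; the measured step of a number 0.81 log units higher from compound 1 to compound 2 (beyond the scatter) came with a methoxy in place of a hydrogen on an aromatic carbon. Compound 3 `O=C(CN1C(=O)c2ccccc2C1=O)NN1C(=O)CSC1c1ccc(Cl)cc1` is not yet measured. It differs from compound 1 in one place: chloro in place of methoxy on an aromatic carbon. Among the compounds with values here, no measured step trades a methoxy for a chloro, so the one step in hand shows only how much adding a methoxy moved the number, and it gives no direct reading for a chlorine. Relative to compound 1, compound 3 is nonetheless expected to lie somewhat higher, an estimated step of a number 0.73 log units higher from compound 1 to compound 3 (beyond the scatter), with a wide margin. The value expected for compound 3 in this assay is 2.7, between 2.3 and 3.1.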

Compound 3, partition coefficient: 3.21
Compound 3: the middle estimate sits 0.51 log units below what was measured; measured number outside the range, above it.
By their numbers in this assay, from the lowest: compound 1; then compound 2; then compound 3.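

For the compounds shown here, at this place on the aromatic ring, a single chloro in place of the methoxy moves the number in this assay further than the one step seen before did (this is a number 1.24 log units higher from compound 1 to compound 3 (beyond the scatter)). The 4-chlorophenyl compound also stands above the 3,4-dimethoxyphenyl compound (this is a number 0.43 log units higher from compound 2 to compound 3 (beyond the scatter)), so among these three compounds, a second methoxy does not reach the number given by swapping the first methoxy for one chlorine. Nothing shown here explains why the number moves in this way.

Still open, as far as these compounds go, is how other groups at this same place would read, such as a fluoro, a methyl, an amine or a carboxylic acid. From the compounds shown here alone, it is also open whether the swap from methoxy to chloro would give a step of similar size on a different core.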